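Sulfur in Place of Selenium on the Aromatic Carbon

This account rests on a few compounds, and the source may have more. Where it says the series, first, only, none or still open, it means among the compounds named here.

Measured compounds:
compound 1 `CCCCC[Se]c1nc(NCc2ccc(SC)cc2)c2ccccc2n1`; in an ADME assay on 184B5 cells (Homo sapiens) for cytotoxicity, read by MTT assay, with a stated time of 72 h (a lower number here means a stronger inhibitor of growth, a higher number a weaker inhibitor of growth), compound 1 gives a limit, > 100000 nM.
compound 2 `CCCCCSc1nc(NCc2ccc([Se]C)cc2)c2ccccc2n1`; in this assay compound 2 gives a limit, > 100000 nM.
compound 3 `CSc1nc(NCc2ccc([Se]C)cc2)c2ccccc2n1`; in this assay compound 3 gives a limit, > 100000 nM.

Compound 3 therefore stands only at a limit of this assay, with no number of its own. The same holds for the whole set, since (the limit of > 100000 nM in this assay, at which 3 of the 3 values shown sit). Among the compounds with values here, the one step that can be traced between measured compounds is a step that the two limits leave unreadable from compound 2 to compound 3, and both its ends are limits, so its size cannot be read.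

Compound 4 `CSc1ccc(CNc2nc(SC)nc3ccccc23)cc1` differs from compound 3 by a group of 2 heavy atoms (1 carbon, 1 sulfur; no ring) in place of a group of 2 heavy atoms (1 carbon, 1 selenium; no ring), on an aromatic carbon. Within the data shown here, no measured step touches this change, and the single measured step is unreadable. Compound 4 is thus expected to remain at the limit, estimated at 150000 nM with a range from 50000 nM to 500000 nM. The estimated step is a step that the limit leaves unreadable from compound 3 to compound 4, meaning no change expected beyond the scatter.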

Compound 4, concentration for total growth inhibition: > 100000 nM
Compound 4 was reported as a limit (the forecaster's own chance of this, stated with the estimate: 85%); the middle value lies beyond the limit too.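

In this assay compound 4 gives > 100000 nM, which is a limit and not a number. Its steps from compound 1 and from compound 3 join limits at both ends, so neither can be read. The compounds shown leave open whether exchanging selenium and sulfur changes growth inhibition at all: the limit of > 100000 nM in this assay, at which 4 of the 4 values shown sit.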